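The source may hold more compounds than are shown below. What is called first, only, known or untested is meant among the compounds shown, and "the series" means these compounds.

Compound 3 `COc1ccc(/C=C/C(=O)CC(C)=O)cc1OC` gives 8200 nM in an ADME assay on HEK293 cells (Homo sapiens) for cytotoxicity, read by MTT assay, with a stated time of 72 h (a higher number here means a weaker inhibitor, a lower number a stronger inhibitor), the lowest of the three numbers; compound 1 `COc1ccc(/C=C/c2cc(C)n[nH]2)cc1` gives 12900 nM there and compound 2 `COc1ccc(/C=C/c2cc(C)no2)cc1OC` gives 63200 nM. The step of a 7.7-fold lower number from compound 2 to compound 3 (0.89 log units; beyond the scatter) is the only measured one bearing on the change to compound 4 `COc1ccc(/C=C/c2cc(C)n[nH]2)cc1OC`, which carries 3-methyl-1H-pyrazol-5-yl in place of (2-oxopropyl)carbonyl on a double-bonded chain carbon bound to a double-bonded chain carbon. That step, in which a five-membered aromatic ring gave way to the same chain, lowered the number, so the reverse kind of swap here may raise it; compound 1, which already carries the entering ring, shows a value within the scatter of compound 3. Compound 4 is therefore expected to show a 1.7-fold higher number from compound 3 to compound 4 (0.23 log units; within the scatter), landing at an estimated 14000 nM, with a range from 5000 nM to 40000 nM.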

Compound 4, half-maximal inhibitory concentration: 23200 nM
Beside the measured number, compound 4's estimate is 1.7-fold (0.22 log units) below it; the range from low to high includes it.
By their numbers in this assay, from the lowest: compounds 3, 1 and 4 (each within the scatter of the next, the first and the last beyond it); then compound 2.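

In this assay, 3-methyl-1H-pyrazol-5-yl in place of (2-oxopropyl)carbonyl on this double-bonded chain carbon gives a clear shift (a 2.8-fold higher number from compound 3 to compound 4 (0.45 log units; beyond the scatter)), so the open chain keeps the lowest number against both five-membered aromatic rings. Those two rings also do not read alike at this place (a 2.7-fold lower number from compound 2 to compound 4 (0.44 log units; beyond the scatter)). Methoxy in place of hydrogen on an aromatic carbon leaves a step that stays within the scatter (a 1.8-fold higher number from compound 1 to compound 4 (0.25 log units; within the scatter)). No evidence here explains these differences. Still open, as far as these compounds go, is how an amine, a carboxylic acid or a longer chain would read at this place.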